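Methoxy to (cyclopropylmethyl)amino at a clearance limit

This account rests on a few compounds, and the source may have more. Where it says the series, first, only, none or still open, it means among the compounds named here.

Values in an in vitro ADME assay on microsomes from liver (Homo sapiens) for metabolic stability; on this read-out lower numbers stand for slow clearance and higher numbers for fast clearance:
- compound 1 `Cc1ccc(Cn2c(=O)[nH]c3c(N)nc(C(F)(F)F)cc32)cn1`: < 7 mL.min-1.g-1
- compound 2 `Cc1nc(Cn2c(=O)[nH]c3c(N)nc(C(F)(F)F)cc32)co1`: < 8 mL.min-1.g-1
- compound 3 `COc1ccc(Cn2c(=O)[nH]c3c(N)nc(C(F)(F)F)cc32)cn1`: < 8 mL.min-1.g-1

Compound 3 stands at a limit, < 8 mL.min-1.g-1, and has no exact number. The other two compounds also gave only limits. Compound 4 `Nc1nc(C(F)(F)F)cc2c1[nH]c(=O)n2Cc1ccc(NCC2CC2)nc1` has (cyclopropylmethyl)amino in place of methoxy on an aromatic carbon. The closest measured change at that carbon is a step that the two limits leave unreadable from compound 1 to compound 3. The change in the attached ring, a step that the two limits leave unreadable from compound 2 to compound 3, gives no size either. With no readable size to carry over, the expectation rests on the structural change alone. A moderate rise in this assay is expected, with the estimated step of an at least 1.5-fold higher number from compound 3 to compound 4 (0.17 log units; that floor lies within the scatter). For compound 4 the estimated value is 12 mL.min-1.g-1, with an expected range of 7 mL.min-1.g-1 to 30 mL.min-1.g-1.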

Compound 4, intrinsic clearance in microsomes: 121 mL.min-1.g-1
Compound 4: the middle estimate sits 10-fold (1.00 log units) below what was measured; the measured number lies above the stated range.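

Putting (cyclopropylmethyl)amino on this aromatic carbon, next to the ring nitrogen, gives in this assay an at least 15-fold higher number from compound 3 to compound 4 (1.17 log units; beyond the scatter) against methoxy and an at least 17-fold higher number from compound 1 to compound 4 (1.23 log units; beyond the scatter) against methyl. Among the compounds shown here, this is the first readable size at this position, and it shows that the group on this carbon can move the read-out well beyond the scatter. For the compounds shown here, the steps among the earlier compounds cannot be read, because their values are limits: the limit of < 8 mL.min-1.g-1 in this assay, at which 2 of the 4 values shown sit. It stays open whether the rise follows the cyclopropyl ring or the amine nitrogen, since the compounds shown include neither a simple methylamino group nor a cyclopropylmethoxy group on this carbon.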